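This account rests on a few compounds, and the source may have more. Where it says the series, first, only, none or still open, it means among the compounds named here.

Compound 3 `COC(=O)[C@@H]1CCCN1C(=O)NCc1ccc(C(=O)N2CCCCc3ccccc32)cc1C` gives 100 nM in a functional assay on HEK293 cells for agonist activity at Vasopressin V2 receptor (Homo sapiens), read by a luciferase reporter and cAMP accumulation (on this read-out higher numbers stand for an effect only at larger amounts of compound and lower numbers for an effect already at smaller amounts), the second highest of the three numbers in hand. Its nearest neighbour is compound 2 `Cc1cc(C(=O)N2CCCCc3ccccc32)ccc1CNC(=O)NCC(=O)N1CCCCC1`, with 150 nM, and the gap a 1.5-fold lower number from compound 2 to compound 3 (0.18 log units; within the scatter) is within the scatter. Its furthest is compound 1 `COC(=O)CNC(=O)NCc1ccc(C(=O)N2CCCCc3ccccc32)cc1C`, with 37 nM; the step of a 2.7-fold higher number from compound 1 to compound 3 (0.43 log units; beyond the scatter) is modest but real. Compound 4 `Cc1cc(C(=O)N2CCCCc3ccccc32)ccc1CNC(=O)N1CCC[C@H]1C(=S)N(C)C` differs from compound 3 in one place: a group of 5 heavy atoms (3 carbon, 1 nitrogen, 1 sulfur; no ring) in place of a group of 4 heavy atoms (2 carbon, 2 oxygen; no ring), on a saturated ring carbon. The measured step that bears most on this change is a 4.1-fold higher number from compound 1 to compound 2 (0.61 log units; beyond the scatter), where a methoxy on a carbonyl carbon gave way to piperidin-1-yl and the number rose; the step of a 2.7-fold higher number from compound 1 to compound 3 (0.43 log units; beyond the scatter) also left the methoxycarbonyl in place within a ring and cost a little. A new group on the same saturated ring carbon, in which the methoxycarbonyl leaves, is therefore expected to shift this assay by a modest amount upward, of the order of a 2.0-fold higher number from compound 3 to compound 4 (0.30 log units; within the scatter). Compound 4 is accordingly estimated at 200 nM, with a range from 70 nM to 600 nM.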

Compound 4, half-maximal effective concentration: 3.2 nM
Compound 4: the middle estimate sits 63-fold (1.80 log units) above what was measured; measured number outside the range, below it.
By their numbers in this assay, from the lowest: compound 4; then compound 1; then compounds 3 and 2 (each within the scatter of the next).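

In this assay, within the data shown here, the saturated ring carbon proves far more responsive than the earlier compounds indicated: with the sulfur-bearing group in place of methoxycarbonyl there is a 31-fold lower number from compound 3 to compound 4 (1.49 log units; beyond the scatter) on this change, against only modest steps or steps within the scatter among the earlier compounds. The larger exchanges on the carbonyl carbon agree, with a 47-fold lower number from compound 2 to compound 4 (1.67 log units; beyond the scatter) and a 12-fold lower number from compound 1 to compound 4 (1.06 log units; beyond the scatter), so compound 4 has the lowest number of the four, beyond the scatter against each of the others. Nothing at hand accounts for the size of this step.

As far as these compounds go, whether the sulfur or the dimethylamino part carries the step stays open, and a dimethylcarbamoyl group, with oxygen in place of sulfur, would separate the two. From the compounds shown here alone, how a carboxylic acid or a longer chain on this ring carbon would read is also open.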